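This account rests on a few compounds, and the source may have more. Where it says the series, first, only, none or still open, it means among the compounds named here.

In a functional assay on HeLa cells (Homo sapiens) for antiproliferative activity, read by CCK-8 assay, with a stated time of 72 h (on this read-out lower numbers stand for stronger inhibition and higher numbers for weaker inhibition), compound 1 (`COc1cc(-c2ncncc2-c2ccc(SC)cc2)cc(OC)c1OC`) gives 220 nM and compound 2 (`CCOc1ccc(-c2cncnc2-c2cc(OC)c(OC)c(OC)c2)cc1`) gives 250 nM. The gap between them is a 1.1-fold higher number from compound 1 to compound 2 (0.06 log units; within the scatter). Compound 3 (`COc1cc(-c2ncncc2-c2ccc(OC(C)C)cc2)cc(OC)c1OC`) gives 8360 nM, the highest number of the three and the weakest inhibition. The steps up to it are a 38-fold higher number from compound 1 to compound 3 (1.58 log units; beyond the scatter) and a 33-fold higher number from compound 2 to compound 3 (1.52 log units; beyond the scatter). Compound 4 (`COc1cc(-c2ncncc2-c2ccc(C(=O)N(C)C)cc2)cc(OC)c1OC`) carries dimethylcarbamoyl in place of isopropoxy on an aromatic carbon, para to a large group: dimethylcarbamoyl in place of isopropoxy on an aromatic carbon. Among the compounds with values here, no measured compound carries this group, so those large steps show only that changes at this place can move the number widely. Compound 3 sits at the top after a 33-fold higher number from compound 2 to compound 3 (1.52 log units; beyond the scatter), so a moderate fall is expected, with wide uncertainty. The expected size is a 3.3-fold lower number from compound 3 to compound 4 (0.52 log units; beyond the scatter). For compound 4 the estimated value is 2500 nM, with an expected range from 350 nM to 15000 nM.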

Compound 4, half-maximal inhibitory concentration: 790 nM
Estimate against measurement, compound 4: 3.2-fold (0.50 log units) above; low and high end bracket the measured number.
By their numbers in this assay, from the lowest: compounds 1 and 2 (each within the scatter of the next); then compound 4; then compound 3.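

Within this assay this place accepts a group attached through a carbonyl: dimethylcarbamoyl in place of isopropoxy gives an 11-fold lower number from compound 3 to compound 4 (1.02 log units; beyond the scatter) and so undoes most of the loss seen with isopropoxy. It still does not match the ethoxy or methylsulfanyl compounds, with a 3.2-fold higher number from compound 2 to compound 4 (0.50 log units; beyond the scatter) and a 3.6-fold higher number from compound 1 to compound 4 (0.56 log units; beyond the scatter) as modest steps. Nothing measured here accounts for these gaps. On these data alone, whether an amine, a carboxylic acid or the unsubstituted carboxamide would close the remaining gap stays open. So does whether longer chains on the amide nitrogen would move the number toward that of compound 3.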